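The compounds below may be only part of what the source reports. "The series", "measured", "known", "first", "only" and "open" are said of these compounds alone.

Compound 1 `CCN(CC)c1ccc(-c2cccc(Cl)c2)nn1` gives > 25000 nM 
Compound 2 `CCN(CC)c1ccc(-c2cccc(C#N)c2)nn1` gives > 25000 nM 

In a functional assay on PC-3 cells (Homo sapiens) for antiproliferative activity, with a stated time of 48 h (on this read-out lower numbers stand for stronger inhibition and higher numbers for weaker inhibition), compound 1 gives > 25000 nM as a limit of the assay and not a number. Compound 2 likewise gives > 25000 nM as a limit. Going by the values given here, the only measured step is a step that the two limits leave unreadable from compound 1 to compound 2 and it offers no size to carry forward, with both compounds at one limit (the limit of > 25000 nM in this assay, at which 2 of the 2 values shown sit). Compound 3 `CCOC(=O)c1cccc(-c2ccc(N(CC)CC)nn2)c1` carries ethoxycarbonyl in place of cyano on an aromatic carbon. With no measured gain to build on, the estimated change is a step that the limit leaves unreadable from compound 2 to compound 3 and no clear strengthening of inhibition is expected. Compound 3 is expected at 30000 nM with an estimated range from 12000 nM to 60000 nM and may well be only a limit.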

Compound 3, half-maximal inhibitory concentration: > 25000 nM
Compound 3 ended at the assay's limit; the forecaster's own chance of this, stated with the estimate: 75%; the middle value lies beyond the limit too.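

The steps among compound 1, compound 2 and compound 3 cannot be read, because each value is a limit of the assay and not a number: the limit of > 25000 nM in this assay, at which 3 of the 3 values shown sit. The compounds shown leave open whether chloro, cyano or ethoxycarbonyl differ at all in this assay.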